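Hydroxymethyl-to-hydrogen step on the hydroxybutynylthio chains

The compounds below may be only part of what the source reports. "The series", "measured", "known", "first", "only" and "open" are said of these compounds alone.

Measured compounds:
- compound 1 `OCC#CCSc1cnc2ccccc2c1SCC#CCO`: 2.6 ug/mL
- compound 2 `C[Se]c1c(SCC#CCO)cnc2ccccc12`: 2.1 ug/mL
- compound 3 `C#CCSc1c(SCC#CCO)cnc2ccccc12`: 2.7 ug/mL

The series is followed in a functional assay on CCRF-CEM cells (Homo sapiens) for cytotoxicity, read by sulforhodamine B assay, with a stated time of 72 h; on this read-out lower numbers stand for stronger inhibition and higher numbers for weaker inhibition. Compound 1 stands second highest of the three numbers; its nearest neighbour is compound 3, at a 1.0-fold higher number from compound 1 to compound 3 (0.02 log units; within the scatter), and its furthest is compound 2, at a 1.2-fold lower number from compound 1 to compound 2 (0.09 log units; within the scatter). All three values lie within the scatter of one another, so no order among them can be read.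

The next compound, compound 4 `C#CCSc1cnc2ccccc2c1SCC#CCO`, differs from compound 1 by hydrogen in place of hydroxymethyl on a triple-bonded carbon. Compound 3 already shows this same change relative to compound 1, carried out on the other of the two chains of the shared core, and there it gave a 1.0-fold higher number from compound 1 to compound 3 (0.02 log units; within the scatter), a step within the scatter. The step from compound 2 to compound 3 is a different kind of change and does not bear directly on this one. Going by the values given here, no measured step therefore points to movement in this assay beyond the scatter in either direction.

Compound 4 is accordingly expected to sit close to compound 1, with an estimated no change at the digits printed from compound 1 to compound 4 (within the scatter), giving an expected value of 2.6 ug/mL within a range of 1.3 ug/mL to 5.2 ug/mL.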

Compound 4, concentration for 50% inhibition: 3.2 ug/mL
The estimate for compound 4 lay 1.2-fold (0.09 log units) below the measured number; the range from low to high includes it.
By their numbers in this assay, from the lowest: compounds 2, 1, 3 and 4 (each within the scatter of the next).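

In this assay the change of 4-hydroxybut-2-yn-1-yl to propargyl gives a 1.2-fold higher number from compound 1 to compound 4 (0.09 log units; within the scatter) on this chain, and it stands with a 1.0-fold higher number from compound 1 to compound 3 (0.02 log units; within the scatter) on the other chain of the shared core. Until now, this replacement of hydroxymethyl by hydrogen on a triple-bonded carbon had been read on one chain only; it now stays within the scatter on each chain when made singly. Going by these compounds alone, for compounds 1, 3 and 4, the hydroxymethyl on either chain can therefore give way to hydrogen with no step that can be read in this read-out, while the other chain keeps its hydroxymethyl. The data on hand offer no explanation for this flat result.

The compounds shown leave open whether propargyl on both chains at once would also stay within the scatter, as each single change does here. They also leave open whether a larger change on the same triple-bonded carbon, such as an aminomethyl group, a carboxylic acid or a longer hydroxyalkyl chain in place of hydroxymethyl, would produce a step beyond the scatter.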